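A few compounds are considered here, and "the series" means these few. Any claim that something is new, unique, unknown or untested is made for them only; others in the source may bear on it.

Measured so far:
compound 1 `CCCCCCCCCCCCNc1nc(O)c2ncnc-2c(O)n1`: > 500 ug/mL
compound 2 `CCCCCCCCCCCCNc1nc(=O)c2c(ncn2[C@H]2C[C@H](O)[C@@H](CO)O2)c(=O)[nH]1`: > 500 ug/mL
compound 3 `CCCCCCCCCCCCCCCCNc1nc(=O)c2ncn([C@@H]3O[C@H](CO)[C@@H](O)[C@H]3O)c2c(=O)[nH]1`: 30 ug/mL

In an assay on isolated protein for inhibition of ATP-dependent RNA helicase SUPV3L1, mitochondrial (Homo sapiens) (on this read-out lower numbers stand for stronger inhibition and higher numbers for weaker inhibition), compound 1 reaches only a limit of the assay. Compound 2 likewise reaches only a limit in this assay. For the measured compounds named here, compound 3 is therefore the one compound with an actual number in this assay, and it stands alone; the two other values sit at the limit of > 500 ug/mL in this assay, at which 2 of the 3 values shown sit, and cannot be ordered against it. Compound 4 `CCCCCCCCCCCCNc1nc(=O)c2ncn([C@@H]3O[C@H](CO)[C@@H](O)[C@H]3O)c2c(=O)[nH]1` keeps the core and sugar of compound 3 and differs by hydrogen in place of butyl on a saturated chain carbon, ten or more bonds along the chain from a nitrogen on an aromatic ring. Compound 1 and compound 2 carry the shorter chain and give only limits, so a weakening step is expected: compound 4 is expected to fall from compound 3 by a 5.0-fold higher number from compound 3 to compound 4 (0.70 log units; beyond the scatter). Compound 4 is thus estimated at 150 ug/mL, between 40 ug/mL and 500 ug/mL.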

Compound 4, half-maximal inhibitory concentration: 150 ug/mL
The estimate for compound 4 equals the measured number at the digits printed, within the range that was stated.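

For the compounds shown here, replacing butyl with hydrogen gives a 5.0-fold higher number from compound 3 to compound 4 (0.70 log units; beyond the scatter) in this assay, the first change here that reads as a step. Chain length at this place therefore matters, yet compound 4 still gives a real number rather than a limit. Compound 1 and compound 2 remain limits and offer no such reading: the limit of > 500 ug/mL in this assay, at which 2 of the 4 values shown sit.

From the compounds shown here alone, whether a longer chain would lower the number further remains open. So does the effect of an amine or a carboxylic acid in place of butyl.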